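This account rests on a few compounds, and the source may have more. Where it says the series, first, only, none or still open, it means among the compounds named here.

Working notes on the series. Compound 1 `COc1ccc(-c2cc(-c3ccc(NS(C)(=O)=O)cc3)cnc2N)cn1` and compound 2 `COc1ccc(-c2cc(-c3ccc(C(=O)O)cc3)cnc2N)cn1` share one core and differ only in one substituent on an aromatic carbon. In a physicochemical assay for solubility, read by nephelometry, measured as kinetic solubility, at pH 2 (on this read-out higher numbers stand for higher solubility and lower numbers for lower solubility), compound 1 gives > 100 ug/mL, which is a limit of the assay rather than a number. In this assay, among the measured compounds shown here, compound 2 gives 12.5 ug/mL, the only true number in hand. For the measured compounds named here, of the two values measured so far, one sits at the limit of > 100 ug/mL in this assay, at which 1 of the 2 values shown sits. Going by the values given here, the single measured step, an at least 8.0-fold lower number from compound 1 to compound 2 (0.90 log units; beyond the scatter), is the only guide the series offers.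

Compound 3 `COc1ccc(-c2cc(-c3ccc(C(N)=O)cc3)cnc2N)cn1` has not yet been measured in this assay. Relative to compound 2 it carries amino in place of hydroxy on a carbonyl carbon, so carboxy becomes carbamoyl. Among the compounds with values here, no measured step swaps hydroxy for amino on a carbonyl carbon; the step from compound 1 to compound 2 concerns a different exchange on the same aromatic carbon and gives no direct precedent. For compound 3 the expected step is therefore a 1.6-fold higher number from compound 2 to compound 3 (0.20 log units; within the scatter), within or only just beyond the scatter. For compound 3 the estimate is 20 ug/mL, with a range from 6 ug/mL to 70 ug/mL.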

Compound 3, solubility: > 100 ug/mL
Compound 3 ended at the assay's limit; the forecaster's own chance of this, stated with the estimate: 15%; at least 5.0-fold (0.69 log units) between middle value and limit.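

Amino in place of hydroxy on a carbonyl carbon, a change that turns carboxy into carbamoyl, gives an at least 8.0-fold higher number from compound 2 to compound 3 (0.90 log units; beyond the scatter) in this assay, so a single atom exchange on this carbonyl carbon is enough to move the read-out beyond the scatter. Compound 1 alone could not show whether its high reading was particular to methanesulfonamido, but with carbamoyl on the same aromatic carbon, the low true number now belongs only to carboxy among the three compounds shown. In this assay compound 3 gives > 100 ug/mL, which is a limit of the assay and not a number, and the top of the range now holds most of the series: the limit of > 100 ug/mL in this assay, at which 2 of the 3 values shown sit.

From the compounds shown here alone, the step between the methanesulfonamido and carbamoyl compounds cannot be read, so their order in this assay stays unknown, as does how far either lies past the limit. Also open, going by these compounds, is where a nitrile, a methyl ester or an aminomethyl group on the same aromatic carbon would fall relative to the carboxy of compound 2.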